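The compounds below may be only part of what the source reports. "The series", "measured", "known", "first", "only" and "open" are said of these compounds alone.

Going by the values given here, in a functional assay on MCF7 cells (Homo sapiens) for antiproliferative activity (a lower number here means a stronger inhibitor, a higher number a weaker inhibitor), compound 1 `CCONC(=O)c1sc(N2N=C(c3ccc(C)cc3)CC2c2cc3cc(OC)ccc3nc2Cl)nc1C` gives 38 nM, and compound 2 `CNC(=O)c1sc(N2N=C(c3ccc(C)cc3)CC2c2cc3cc(OC)ccc3nc2Cl)nc1C` gives 38 nM, which places compound 2 level with the only other measured compound. Compound 3 `COc1ccc2nc(Cl)c(C3CC(c4ccc(C)cc4)=NN3c3nc(C)c(/N=N/c4ccccc4)s3)cc2c1` keeps the shared core and differs from compound 2 on an aromatic carbon next to the ring sulfur: a group of 8 heavy atoms (6 carbon, 2 nitrogen; one six-membered aromatic ring of carbon only) in place of a group of 4 heavy atoms (2 carbon, 1 nitrogen, 1 oxygen; no ring), on an aromatic carbon. The methylcarbamoyl group leaves, and a larger group with a six-membered aromatic ring of carbon only enters. Just one measured step bears on this change, no change at the digits printed from compound 1 to compound 2 (within the scatter). That step stayed within the scatter, but it only altered the group on an amide-type nitrogen, and both measured compounds retain the carbonyl. Among the compounds with values here, no measured compound shows what happens when the whole methylcarbamoyl group is replaced, so the data give no direct guide to the size of this larger change. A moderate loss in this assay is expected, with wide uncertainty in both directions. The expected change is a 2.6-fold higher number from compound 2 to compound 3 (0.42 log units; beyond the scatter), towards weaker inhibition. For compound 3 the estimated value is 100 nM, with an expected range from 20 nM to 500 nM.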

Compound 3, half-maximal inhibitory concentration: 38 nM
Compound 3: middle estimate off by 2.6-fold (0.42 log units), on the high side; the range from low to high includes it.
By their numbers in this assay, from the lowest: compounds 1, 2 and 3 (each within the scatter of the next).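

In this assay, replacing the whole methylcarbamoyl group on the aromatic carbon next to the ring sulfur with the larger group bearing a six-membered aromatic ring of carbon only gives no change at the digits printed from compound 2 to compound 3 (within the scatter). The comparison with the group of compound 1 reads the same, with no change at the digits printed from compound 1 to compound 3 (within the scatter), so the insensitivity seen earlier for a change on the amide-type nitrogen now extends to a replacement of the entire group, including its carbonyl. Across compounds 1, 2 and 3, this position therefore accepts a group of 8 heavy atoms with 0 hydrogen-bond donors and still gives the same printed value as the methylcarbamoyl group, which has 4 heavy atoms and 1 hydrogen-bond donor. Nothing available explains why the value holds through this change.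

The compounds shown leave open whether the value would also hold with a small group at this position, such as a single methyl or a hydrogen, or with an amine or a carboxylic acid. They also leave open whether a phenyl ring joined directly to this carbon, without the two nitrogens of the entering group, would give the same value.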